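Notes on a biaryl amide series: cytotoxicity in HEK293 cells

The compounds below may be only part of what the source reports. "The series", "measured", "known", "first", "only" and "open" are said of these compounds alone.

Measured so far in an ADME assay on HEK293 cells (Homo sapiens) for cytotoxicity, read by CellTiter-Glo and resazurin assay, with a stated time of 72 h; on this read-out lower numbers stand for an effect already at smaller amounts and higher numbers for an effect only at larger amounts of compound:
- compound 1 `CC(C)N(Cc1cccc(OCCCCCC(=O)O)c1)C(=O)c1ccc(-c2cccc3ccccc23)cc1`: > 26000 nM, a limit of the assay
- compound 2 `CCOC(=O)CCCCCOc1cccc(CN(C(=O)c2ccccc2)C(C)C)c1`: > 26000 nM, a limit of the assay
- compound 3 `CCOC(=O)CCCCCOc1cccc(CN(C(=O)c2ccc(-c3cccc(N(C)C)c3)cc2)C(C)C)c1`: > 26000 nM, a limit of the assay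

Compound 3 therefore stands only at a limit in this assay. Within the data shown here, the one step that can be traced, a step that the two limits leave unreadable from compound 2 to compound 3, is left unreadable by the two limits. All three values sit at the same limit (the limit of > 26000 nM in this assay, at which 3 of the 3 values shown sit), so nothing on the numbers separates the compounds.

Compound 4 `CCOC(=O)CCCCCOc1cccc(CN(C(=O)c2ccc(-c3cccc4ccccc34)cc2)C(C)C)c1` differs from compound 3 by naphthalen-1-yl in place of 3-(dimethylamino)phenyl on an aromatic carbon. Among the measured compounds shown here, no measured step bears on this change, and the aryl step seen so far gave no readable size. The expected step that the limit leaves unreadable from compound 3 to compound 4 is none beyond the scatter. Compound 4 is estimated at 30000 nM (range 10000 nM to 100000 nM) in this assay, most likely again only a limit.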

Compound 4, half-maximal effective concentration: > 26000 nM
Compound 4 gave a limit, no number; the forecaster's own chance of this, stated with the estimate: 80%; the middle value does not contradict the limit.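

No step to compound 4 from compound 1, compound 2 or compound 3 can be read in this assay, since each value is a limit and all coincide: the limit of > 26000 nM in this assay, at which 4 of the 4 values shown sit.

The compounds shown leave open whether any of these changes alters cytotoxicity, and at what concentration any of them would show an effect.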